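Replacing the Chlorophenyl of Compound 2 with Methylaminophenyl

The source may hold more compounds than are shown below. What is called first, only, known or untested is meant among the compounds shown, and "the series" means these compounds.

Measured compounds:
Compound 1, `CC(C)c1ccc(-c2cc(Cl)cc(C(=O)Nc3nn[nH]n3)n2)cc1`: 68%
Compound 2, `COc1cc(C(=O)Nc2nn[nH]n2)nc(-c2cccc(Cl)c2)c1`: 34%

In a functional assay on the whole organism with Rattus norvegicus as the target, at a dose of 3 mg/kg by the oral route (a higher number here means a stronger effect of the compound at the dose given, a lower number a weaker effect), compound 1 gives 68%, and compound 2 gives 34%. Compound 2 stands lowest of these two values, with compound 1 higher by more than the usual scatter. Compound 3, `CNc1ccc(-c2cc(OC)cc(C(=O)Nc3nn[nH]n3)n2)cc1`, has not been measured yet. Compared with compound 2 it differs in one place: 4-(methylamino)phenyl in place of 3-chlorophenyl on an aromatic carbon. For the measured compounds named here, no measured pair shows this kind of change, so its effect is unknown. A small step is expected in this assay, a number 6 percentage points higher from compound 2 to compound 3 (within the scatter), which may well lie within the scatter. Compound 3 is therefore estimated at 40%, within a range from 15% to 70%.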

Compound 3, a percentage reported as inhibition, in the whole organism at one dose (the size of the read-out at that dose, not a potency): 79%
For compound 3 the middle estimate is 39 percentage points below the measured one; measured number outside the range, above it.
By their numbers in this assay, from the lowest: compound 2; then compound 1; then compound 3.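

The group on this aromatic carbon, next to the ring nitrogen, strongly affects the result in this assay: 4-(methylamino)phenyl in place of 3-chlorophenyl gives a number 45 percentage points higher from compound 2 to compound 3 (beyond the scatter). This single change removes the chlorine, adds a nitrogen-bearing group with a hydrogen-bond donor and acceptor, and shifts the substituent's place on the phenyl ring. Nothing available explains the rise. Going by these compounds, it remains open which of these differences matters. A plain amine or a dimethylamino group on the same phenyl ring would help separate them.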